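The source may hold more compounds than are shown below. What is called first, only, known or untested is meant among the compounds shown, and "the series" means these compounds.

Measured in a functional assay on K562 cells (Homo sapiens), read by MTT assay, with a stated time of 72 h; on this read-out lower numbers stand for stronger inhibition and higher numbers for weaker inhibition:
- Compound 1 `Cc1ncnc2c1c(-c1cc3ccccc3o1)cn2[C@@H]1O[C@H](CO)[C@@H](O)[C@H]1O`: > 20000 nM
- Compound 2 `Nc1nc(N)c2c(-c3ccco3)cn([C@@H]3O[C@H](CO)[C@@H](O)[C@H]3O)c2n1`: > 20000 nM
- Compound 3 `COc1nc(N)nc2c1c(-c1ccco1)cn2[C@@H]1O[C@H](CO)[C@@H](O)[C@H]1O`: > 20000 nM

Compound 3 gives only a limit of the assay, > 20000 nM, and not a number. The other two results are limits as well: the limit of > 20000 nM in this assay, at which 3 of the 3 values shown sit. None of the three can therefore be ranked against the others.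

Compound 4 `COc1nc(N)nc2c1c(-c1cc3ccccc3o1)cn2[C@@H]1O[C@H](CO)[C@@H](O)[C@H]1O` differs from compound 3 by having 1-benzofuran-2-yl in place of furan-2-yl on an aromatic carbon.

The only measured step among these compounds is a step that the two limits leave unreadable from compound 2 to compound 3. It concerns a different place on the molecule, so it offers no size to carry over. Compound 1 already carries 1-benzofuran-2-yl on a related core, and its result is the limit > 20000 nM. With no readable step pointing either way, no clear change is expected in this assay, and a further limit is the likeliest result.

The expected change is a number no higher from compound 3 to compound 4 (the limit leaves the size open), and this is only an estimate. Compound 4 is expected near 20000 nM, with an estimated range of 8000 nM to 40000 nM.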

Compound 4, half-maximal inhibitory concentration: 15500 nM
The estimate for compound 4 lay 1.3-fold (0.11 log units) above the measured number; measured number inside the range.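

Swapping furan-2-yl for 1-benzofuran-2-yl on this aromatic carbon gives an at least 1.2-fold lower number from compound 3 to compound 4 (0.11 log units; that floor lies within the scatter) in this assay. With this change, compound 4 gives 15500 nM, a real number rather than a limit, so this position can hold a group that brings a result inside the range of the assay. The step is only a floor, and that floor lies within the usual scatter, so the true size of the change could be small or much larger, and no other compound here offers a number to compare: the limit of > 20000 nM in this assay, at which 3 of the 4 values shown sit.

As far as these compounds go, whether a phenyl ring, an amine or a longer chain on this carbon would lower the number further remains open. So does whether 1-benzofuran-2-yl would have a similar effect with other groups on the shared core.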